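A few compounds are considered here, and "the series" means these few. Any claim that something is new, unique, unknown or untested is made for them only; others in the source may bear on it.

In a functional assay on PC-3 cells (Homo sapiens) for antiproliferative activity, read by MTT assay, with a stated time of 48 h (a higher number here means a weaker inhibitor, a lower number a stronger inhibitor), compound 1 `CCn1c(C(=O)NCCCN(C)C)ccc1C(CC)(CC)c1ccc(OCCC(O)(CC)CC)c(C)c1` gives 2150 nM, compound 2 `CCN(CC)CCNC(=O)c1ccc(C(CC)(CC)c2ccc(OCCC(O)(CC)CC)c(C)c2)n1CC` gives 3350 nM and compound 3 `CCn1c(C(=O)NCCN)ccc1C(CC)(CC)c1ccc(OCCC(O)(CC)CC)c(C)c1` gives 2420 nM. These three share one core and differ only at the end of the chain on the amide. Compound 3 stands level with the other two, since a 1.1-fold higher number from compound 1 to compound 3 (0.05 log units; within the scatter), a 1.4-fold lower number from compound 2 to compound 3 (0.14 log units; within the scatter) and a 1.6-fold higher number from compound 1 to compound 2 (0.19 log units; within the scatter) all lie within the usual scatter.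

Compound 4 `C#CC(C)OC(=O)c1ccc(C(CC)(CC)c2ccc(OCCC(O)(CC)CC)c(C)c2)n1CC` makes a larger change: (1-methylprop-2-yn-1-yl)oxy in place of (2-aminoethyl)amino on a carbonyl carbon, ((1-methylprop-2-yn-1-yl)oxy in place of (2-aminoethyl)amino on a carbonyl carbon). The measured steps bear on this only indirectly. Within the data shown here, they swap one chain end for another, while here the whole chain and the amide-type nitrogen leave, and no measured compound shows that kind of swap. The best starting point is therefore compound 3 at 2420 nM, with no step beyond the scatter expected in this assay, though with wide uncertainty. The estimated step is a 1.2-fold higher number from compound 3 to compound 4 (0.09 log units; within the scatter). For compound 4 the expected value is 3000 nM, within an estimated range of 800 nM to 11000 nM.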

Compound 4, half-maximal inhibitory concentration: 14800 nM
Beside the measured number, compound 4's estimate is 4.9-fold (0.69 log units) below it, and the stated range ends below it.
By their numbers in this assay, from the lowest: compounds 1, 3 and 2 (each within the scatter of the next); then compound 4.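

Until now, changing the chain end on the amide kept every number in this assay within the scatter. Among these compounds, replacing the whole amine-bearing chain on the carbonyl carbon with (1-methylprop-2-yn-1-yl)oxy is the first change to go beyond it, giving a 6.1-fold higher number from compound 3 to compound 4 (0.79 log units; beyond the scatter), a 4.4-fold higher number from compound 2 to compound 4 (0.65 log units; beyond the scatter) and a 6.9-fold higher number from compound 1 to compound 4 (0.84 log units; beyond the scatter), which makes compound 4 the weakest of the four and shows that activity here does respond to what sits on the carbonyl carbon. Nothing measured here explains this step.

The swap removes the terminal amine and the amide-type nitrogen and brings in an ester oxygen and a triple bond all at once, so the compounds shown cannot say which of these matters. A plain methyl ester, or an amide carrying the 1-methylprop-2-yn-1-yl group on its nitrogen, would help to separate them.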